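This account rests on a few compounds, and the source may have more. Where it says the series, first, only, none or still open, it means among the compounds named here.

For the measured compounds named here, compound 1 `O=C(Nc1cc(-c2ccccc2)nn1-c1ccccc1)c1ccccc1` is the only compound with a number in an assay on HEK293 cells for displacement of a labelled ligand from metabotropic glutamate receptor 5 (Rattus norvegicus) (on this read-out lower numbers stand for stronger inhibition and higher numbers for weaker inhibition), where compound 1 gives 4180 nM. Compound 2 `NC(=O)c1ccc(C(=O)Nc2cc(-c3ccccc3)nn2-c2ccccc2)cc1` gives > 10000 nM in this assay, which is a limit of the assay rather than a number. That step, an at least 2.3-fold higher number from compound 1 to compound 2 (0.37 log units; beyond the scatter), ends at the limit of > 10000 nM in this assay, at which 1 of the 2 values shown sits. Compound 3 `N#Cc1cccc(-n2nc(-c3ccccc3)cc2NC(=O)c2ccccc2)c1` differs from compound 1 by cyano in place of hydrogen on an aromatic carbon. Going by the values given here, the one measured step alters a different ring with a different group, so it bears only loosely on this change. Compound 3 is therefore expected to give 5000 nM, between 1500 nM and 15000 nM. The expected step of a 1.2-fold higher number from compound 1 to compound 3 (0.08 log units; within the scatter) may stay within the scatter.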

Compound 3, inhibition constant: > 10000 nM
Compound 3: only a limit was reported (the forecaster's own chance of this, stated with the estimate: 30%); middle value at least 2.0-fold (0.30 log units) from the limit.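

In this assay, the change from phenyl to 3-cyanophenyl gives an at least 2.3-fold higher number from compound 1 to compound 3 (0.37 log units; beyond the scatter). A substituent on this ring therefore also moves the number beyond the scatter, so the loss is no longer confined to the ring changed in compound 2. Both substituted compounds end at a limit rather than a number, so the true size of neither step can be read and the two changes cannot be ranked: the limit of > 10000 nM in this assay, at which 2 of the 3 values shown sit.

From the compounds shown here alone, it remains open whether fluoro, methoxy or an amine in place of cyano at this position would stay close to compound 1. Going by these compounds, it is also open whether cyano elsewhere on this ring would raise the number as well.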